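Methoxycarbonyl in Place of Trifluoromethyl: A Two-Compound Starting Point

The compounds below may be only part of what the source reports. "The series", "measured", "known", "first", "only" and "open" are said of these compounds alone.

Measured so far:
compound 1, `O=[N+]([O-])C1=Cc2cccc(Cl)c2OC1C(F)(F)F`, 3690 nM
compound 2, `O=[N+]([O-])C1=Cc2cc(C#Cc3ccc(C(F)(F)F)cc3)ccc2OC1C(F)(F)F`, 5220 nM

Of the compounds shown here, two have been tested in an assay on 1321N1 cells for antagonist activity at P2Y purinoceptor 6 (Homo sapiens), read by FLIPR and calcium flux; a lower number here means a stronger inhibitor, a higher number a weaker inhibitor. Compound 1, `O=[N+]([O-])C1=Cc2cccc(Cl)c2OC1C(F)(F)F`, gives 3690 nM. Compound 2, `O=[N+]([O-])C1=Cc2cc(C#Cc3ccc(C(F)(F)F)cc3)ccc2OC1C(F)(F)F`, gives 5220 nM. Of these two numbers compound 2 has the higher one, but its gap to compound 1 lies within the usual scatter, so the two read as alike and neither is called the stronger.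

Compound 3, `COC(=O)c1ccc(C#Cc2ccc3c(c2)C=C([N+](=O)[O-])C(C(F)(F)F)O3)cc1`, is not yet measured. It differs from compound 2 in one place: methoxycarbonyl in place of trifluoromethyl on an aromatic carbon. Among the compounds with values here, no measured pair shows this change, so there is nothing to rest a direction on. The expected step of a 1.2-fold lower number from compound 2 to compound 3 (0.06 log units; within the scatter) is small, most likely within the scatter, with no clear direction. Compound 3 is expected to give 4500 nM, with a range from 1500 nM to 13000 nM.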

Compound 3, half-maximal inhibitory concentration: 3970 nM
Estimate against measurement, compound 3: 1.1-fold (0.05 log units) above; measured number inside the range.
By their numbers in this assay, from the lowest: compounds 1, 3 and 2 (each within the scatter of the next).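

Within the data shown here, measured in this assay the swap of trifluoromethyl for methoxycarbonyl on an aromatic carbon, para to a large group, gives a 1.3-fold lower number from compound 2 to compound 3 (0.12 log units; within the scatter) and is the first single-place change with a measured result here. At this position, the two groups read as alike, even though methoxycarbonyl brings hydrogen-bond acceptors and trifluoromethyl has none. Nothing measured here speaks to why these two groups read alike.

On these data alone, the pair covers only these two groups, so it remains open whether a carboxylic acid, an amine or a bare hydrogen on the same carbon would also read alike. One swap also cannot show whether any other group at this position would move the number beyond the scatter.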